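This account rests on a few compounds, and the source may have more. Where it says the series, first, only, none or still open, it means among the compounds named here.

Of the compounds shown here, three have been measured in a functional assay on Jurkat cells (Homo sapiens) for antiproliferative activity, read by MTT assay; a lower number here means a stronger inhibitor, a higher number a weaker inhibitor. Compound 1 `COc1cc2c(cc1OC)C(=O)/C(=C/c1cc(C)cc(C)c1)CC2` gives 4000 nM in this assay. Compound 2 `COc1cc2c(cc1OC)C(=O)/C(=C/c1cc(C)c(O)c(C)c1)CC2` differs from compound 1 by hydroxy in place of hydrogen on an aromatic carbon. In this assay compound 2 gives 4800 nM; the step of a 1.2-fold higher number from compound 1 to compound 2 (0.08 log units; within the scatter) lies within the scatter. Compound 3 `COc1cc2c(cc1OC)C(=O)/C(=C/c1cccc([N+](=O)[O-])c1)C2` gives 22000 nM in this assay, the highest of the three numbers; how its core differs from the core of compound 1 is not broken down here. Compound 4 `COc1cc2c(cc1OC)C(=O)/C(=C/c1cc([N+](=O)[O-])ccc1O)C2` is not yet measured and differs from compound 3 by hydroxy in place of hydrogen on an aromatic carbon, the same kind of change as from compound 1 to compound 2, though the hydroxy there sat ortho to two methyl groups and para to a large group, whereas here it sits ortho to a large group and para to a nitro group. Because the earlier step of a 1.2-fold higher number from compound 1 to compound 2 (0.08 log units; within the scatter) stayed within the scatter, the step from compound 3 to compound 4 is expected to be small, a 1.1-fold higher number from compound 3 to compound 4 (0.04 log units; within the scatter). Compound 4 is therefore estimated at 24000 nM in this assay, within a range from 10000 nM to 60000 nM.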

Compound 4, half-maximal inhibitory concentration: 14500 nM
Compound 4: middle estimate off by 1.7-fold (0.22 log units), on the high side, within the range that was stated.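

In this assay, hydroxy in place of hydrogen on an aromatic carbon again stays within the scatter, with a 1.5-fold lower number from compound 3 to compound 4 (0.18 log units; within the scatter). The two cases do not differ by more than such steps can: the same change on two cores in this assay, a 1.2-fold higher number (0.08 log units; within the scatter) from compound 1 to compound 2 and a 1.5-fold lower number (0.18 log units; within the scatter) from compound 3 to compound 4, 1.8-fold (0.26 log units) apart, within the scatter of two such steps. Going by these compounds alone, this shows that the change had no step beyond the scatter on either of these two cores, but with only two pairs, it does not show that the same would hold on any other core.

The compounds shown leave open whether an amine or a carboxylic acid in place of the hydroxy would give a step beyond the scatter. On these data alone, it also remains open how a nitrile in place of the nitro group would affect the number.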